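Swapping chloro for methoxy on compound 3

A few compounds are considered here, and "the series" means these few. Any claim that something is new, unique, unknown or untested is made for them only; others in the source may bear on it.

Compound 1 `COc1cccc(S(=O)(=O)c2cccc(N)c2C#N)c1`: > 200000 nM (a limit)
Compound 2 `CCCOc1cc(C)cc(S(=O)(=O)c2cccc(N)c2C#N)c1`: 11000 nM
Compound 3 `Cc1cc(Cl)cc(S(=O)(=O)c2cccc(N)c2C#N)c1`: > 200000 nM (a limit)

All three values come from a functional assay on MT4 cells (Homo sapiens) for cytotoxicity; a higher number here means a weaker inhibitor, a lower number a stronger inhibitor. Compound 3 has only a limit, > 200000 nM, which is the limit of > 200000 nM in this assay, at which 2 of the 3 values shown sit. Compound 4 `COc1cc(C)cc(S(=O)(=O)c2cccc(N)c2C#N)c1` differs from it by methoxy in place of chloro on an aromatic carbon. The closest measured step is large: an at least 18-fold higher number from compound 2 to compound 3 (1.25 log units; beyond the scatter). Compound 4 carries methoxy rather than propoxy, however. Compound 1 also carries methoxy, though no methyl group, and it gives only a limit, > 200000 nM. A much smaller move to a lower number is therefore expected, and compound 4 may well stay at the limit. The expected step is an at least 2.0-fold lower number from compound 3 to compound 4 (0.30 log units; that floor lies within the scatter). For compound 4 the estimated value is 100000 nM, with an expected range of 30000 nM to 200000 nM.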

Compound 4, half-maximal inhibitory concentration: 94000 nM
Beside the measured number, compound 4's estimate is 1.1-fold (0.03 log units) above it, and the stated range covers the measured number.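

In this assay, a methyl group added to the ring that carries methoxy gives an at least 2.1-fold lower number from compound 1 to compound 4 (0.32 log units; beyond the scatter), and methoxy in place of chloro gives an at least 2.1-fold lower number from compound 3 to compound 4 (0.32 log units; beyond the scatter). Going by these compounds, both steps start from a limit, so their true sizes remain unknown: the limit of > 200000 nM in this assay, at which 2 of the 4 values shown sit. The chain on the oxygen also matters in this series, as going from propoxy to methoxy gives an 8.5-fold higher number from compound 2 to compound 4 (0.93 log units; beyond the scatter).

On these data alone, whether ethoxy would fall between propoxy and methoxy remains open. So does whether butoxy, a longer chain, or an amine at this place would give a lower number still.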